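This account rests on a few compounds, and the source may have more. Where it says the series, first, only, none or still open, it means among the compounds named here.

Compounds measured so far in a functional assay on MGC-803 cells (Homo sapiens) for antiproliferative activity, read by CCK-8 assay, with a stated time of 72 h, tested at 8 uM; a higher number here means a stronger effect of the compound at the concentration tested, a lower number a weaker effect:

compound 1, `CCN(Cc1ccncc1)C(=S)SCc1ccc(C(=O)Nc2ccccc2N)cc1`, 85.2%
compound 2, `CC1CCN(C(=S)SCc2ccc(C(=O)Nc3ccccc3N)cc2)CC1`, 81.9%
compound 3, `CN(Cc1cccnc1)C(=S)SCc1ccc(C(=O)Nc2ccccc2N)cc1`, 85.5%

Compound 3 holds the highest of the three numbers, but its neighbours lie close: the step of a number 0.3 percentage points higher from compound 1 to compound 3 (within the scatter) and the step of a number 3.6 percentage points higher from compound 2 to compound 3 (within the scatter) are both within the scatter, as is the step of a number 3.3 percentage points lower from compound 1 to compound 2 (within the scatter). On these numbers the three compounds cannot be told apart, and compound 3 cannot be called the strongest; the shared core appears to carry the activity regardless of which of the three groups sits on the thiocarbonyl carbon.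

Compound 4, `CN(Cc1ccncc1)C(=S)SCc1ccc(C(=O)Nc2ccccc2N)cc1`, is the next member to be measured. Its difference from compound 3 is pyridin-4-yl in place of pyridin-3-yl on a saturated chain carbon bound to an amide-type nitrogen. Of the measured steps, the step of a number 0.3 percentage points higher from compound 1 to compound 3 (within the scatter) is the one that bears on this change, since it moves the pyridinyl nitrogen across the same two positions while also exchanging ethyl for methyl on the amide-type nitrogen, and it was within the scatter. Within the data shown here, no measured step isolates the pyridinyl swap alone. The expectation is therefore a step of a number 0.5 percentage points lower from compound 3 to compound 4 (within the scatter), that is, none beyond the scatter in either direction.

Compound 4 is estimated at 85% in this assay, with a range from 77% to 91%.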

Compound 4, a percentage reported as inhibition, at one concentration (the size of the read-out at that concentration, not a potency): 83.2%
Compound 4: middle estimate off by 1.8 percentage points, on the high side; the measured number falls inside the stated range.
By their numbers in this assay, from the lowest: compounds 2, 4, 1 and 3 (each within the scatter of the next).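

In this assay, the change from pyridin-3-yl to pyridin-4-yl on a saturated chain carbon bound to an amide-type nitrogen now stands alone with the rest of the molecule held constant, and a number 2.3 percentage points lower from compound 3 to compound 4 (within the scatter) does not separate the two groups at this position. The other two new comparisons read the same way: hydrogen in place of methyl at that chain carbon gives a number 2 percentage points lower from compound 1 to compound 4 (within the scatter), and methyl((pyridin-4-yl)methyl)amino in place of 4-methylpiperidin-1-yl on the thiocarbonyl carbon gives a number 1.3 percentage points higher from compound 2 to compound 4 (within the scatter), so neither the pyridinyl nitrogen's location, the added methyl nor the exchange of the whole amine group shows any effect in this read-out. No other data are available to interpret these steps.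

On these data alone, all four compounds share the same core and are read at a single concentration, so this read-out gives no potency, and any differences that a full concentration series might reveal remain unknown. Still open, as far as these compounds go, is whether pyridin-2-yl at the chain carbon, or a morpholin-4-yl or a carboxylic acid-bearing group on the thiocarbonyl carbon, would separate from these compounds.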